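This account rests on a few compounds, and the source may have more. Where it says the series, first, only, none or still open, it means among the compounds named here.

Compound 1, `O=C(C1CC1)N1CCc2nc(C#Cc3ccccc3)sc2C1`, carries a cyclopropylcarbonyl group on the ring nitrogen of the shared core. In an assay on HEK293 cells for positive allosteric modulation of metabotropic glutamate receptor 5 (Homo sapiens), read by FLIPR, with a stated time of 1 h (on this read-out lower numbers stand for an effect already at smaller amounts and higher numbers for an effect only at larger amounts of compound), compound 1 gives only a limit, > 10000 nM, and no number. This limit is the limit of > 10000 nM in this assay, at which 1 of the 3 values shown sits. Two measured changes move away from it. Compound 2, `O=C(C1CCC(F)(F)CC1)N1CCc2nc(C#Cc3ccccc3)sc2C1`, gives 70 nM in this assay, a move of an at least 140-fold lower number from compound 1 to compound 2 (2.15 log units; beyond the scatter). Compound 3, `CC1CCCC(C(=O)N2CCc3nc(C#Cc4ccccc4)sc3C2)C1`, gives 100 nM, a move of an at least 100-fold lower number from compound 1 to compound 3 (2.00 log units; beyond the scatter). Between those two lies a 1.4-fold higher number from compound 2 to compound 3 (0.15 log units; within the scatter).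

Compound 4, `CC(C)S(=O)(=O)N1CCc2nc(C#Cc3ccccc3)sc2C1`, differs from compound 1 in a different way: isopropylsulfonyl in place of cyclopropylcarbonyl on an amine nitrogen in a ring. Neither measured step touches the carbonyl itself or the amine nitrogen; both only exchange the ring on the carbonyl carbon, and both were large. They show that a larger ring in that place lowers the number, but say nothing about a sulfonyl. The isopropyl group of compound 4 is no ring at all, so the large drops seen for compound 2 and compound 3 are not expected to carry over. Relative to compound 1, compound 4 is expected to move only little, by a step of an at least 1.2-fold lower number from compound 1 to compound 4 (0.09 log units; that floor lies within the scatter). The estimate for compound 4 in this assay is 8000 nM, with a range from 2000 nM to 30000 nM, and a fair chance that only a limit is reported again.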

Compound 4, half-maximal effective concentration: > 10000 nM
Compound 4 ended at the assay's limit (the forecaster's own chance of this, stated with the estimate: 55%); middle value at least 1.2-fold (0.09 log units) away from the limit.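

In this assay compound 4 gives > 10000 nM, which is a limit and not a number. Among the compounds shown here, compound 1 also stands at a limit, so no step from compound 1 to compound 4 can be read: the limit of > 10000 nM in this assay, at which 2 of the 4 values shown sit. The compounds shown leave open whether isopropylsulfonyl and cyclopropylcarbonyl on the amine nitrogen differ at all in this assay.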